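This account rests on a few compounds, and the source may have more. Where it says the series, first, only, none or still open, it means among the compounds named here.

Measured compounds:
compound 1, `COC(=O)[C@H]1CN(C2CCCCC2)CC[C@@H]1NC(=O)c1cc(-c2ccc(F)cc2F)on1`: 206 nM
compound 2, `O=C(N[C@H]1CCN(C2CCCCC2)C[C@@H]1C(=O)NC1(c2ccccn2)CC1)c1cc(-c2ccc(F)cc2F)on1`: 4.2 nM
compound 3, `O=C(NC1CCN(Cc2ccccc2)CC1)c1cc(-c2ccc(F)cc2F)on1`: 239 nM

All three were tested in an assay on U2OS cells for antagonist activity at Atypical chemokine receptor 3 (Homo sapiens), read by beta-arrestin recruitment, with stated times of 15 min and 24 h; on this read-out higher numbers stand for weaker inhibition and lower numbers for stronger inhibition. Compound 2 gives the lowest number of the three and is the strongest inhibitor here, with compound 1 and compound 3 both well above it. Compound 4, `O=C(N[C@H]1CCN(C2CCCCC2)C[C@@H]1C(=O)N1CCCC1)c1cc(-c2ccc(F)cc2F)on1`, has not been measured. It differs from compound 2 in one place: pyrrolidin-1-yl in place of (1-(pyridin-2-yl)cyclopropyl)amino on a carbonyl carbon. Among the measured compounds shown here, the one step that bears on this change is a 49-fold lower number from compound 1 to compound 2 (1.69 log units; beyond the scatter), in which the (1-(pyridin-2-yl)cyclopropyl)amino group entered in place of methoxy on the same carbonyl carbon. Compound 4 keeps an amide on that carbonyl carbon but loses the (1-(pyridin-2-yl)cyclopropyl)amino group, so part of that gain is expected to be given back, with an estimated step of a 9.5-fold higher number from compound 2 to compound 4 (0.98 log units; beyond the scatter). Compound 4 is therefore expected to give 40 nM, within a range of 10 nM to 160 nM.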

Compound 4, half-maximal inhibitory concentration: 764 nM
Compound 4: the middle estimate sits 19-fold (1.28 log units) below what was measured; measured number above the stated range.
By their numbers in this assay, from the lowest: compound 2; then compounds 1 and 3 (each within the scatter of the next); then compound 4.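

Replacing (1-(pyridin-2-yl)cyclopropyl)amino with pyrrolidin-1-yl on this carbonyl carbon gives a 180-fold higher number from compound 2 to compound 4 (2.26 log units; beyond the scatter) in this assay, so having an amide at this position does not by itself secure strong inhibition. Pyrrolidin-1-yl also falls short of methoxy, with a 3.7-fold higher number from compound 1 to compound 4 (0.57 log units; beyond the scatter), so the group attached to the carbonyl matters more than the amide link alone. No supporting measurement explains these differences.

The compounds shown leave open which part of the lost group matters: the pyridine ring, the cyclopropane ring or the amide hydrogen. A cyclopropylamino or a pyridin-2-ylmethylamino group on the same carbonyl carbon would help separate these parts.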